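This account rests on a few compounds, and the source may have more. Where it says the series, first, only, none or still open, it means among the compounds named here.

Series notes. Compound 1 `O=c1c(C(=S)Nc2ccccc2)coc2ccccc12` is the parent without chloro groups; compound 2 `O=c1c(C(=S)Nc2ccccc2)coc2cc(Cl)c(Cl)cc12` carries two chloro groups on the shared core; compound 3 `O=c1c(C2N=C(c3ccccc3)SS2)coc2ccc(Cl)cc12` carries a different side group and a single chloro. In a functional assay on HEp-2 cells (Homo sapiens) for inhibition, read by sulforhodamine B assay, with a stated time of 48 h (a lower number here means a stronger inhibitor, a higher number a weaker inhibitor), compound 1 gives only a limit, > 100000 nM. In this assay compound 2 likewise gives only a limit, > 100000 nM. Compound 3 gives a measured number in this assay, 74900 nM. Compound 2 therefore stands at the limit of > 100000 nM in this assay, at which 2 of the 3 values shown sit, with no number of its own to rank it against the others.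

Compound 4 `O=c1c(C(=S)Nc2ccccc2)coc2cc(Cl)ccc12` differs from compound 2 in one place: hydrogen in place of chloro on an aromatic carbon. Within the data shown here, no step between two measured compounds is available, so the size of this change cannot be read from the numbers. Compound 1, which lacks chloro altogether, also reaches only a limit in this assay. On that basis no movement beyond the scatter is expected for the change.

Compound 4 is expected to give about 150000 nM in this assay, within 60000 nM to 400000 nM, most probably reported again only as a limit. The expected step is a step that the limit leaves unreadable from compound 2 to compound 4.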

Compound 4, half-maximal inhibitory concentration: > 100000 nM
Compound 4 was reported as a limit; the forecaster's own chance of this, stated with the estimate: 75%; the middle value is on the limit's open side.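

No new step can be read among compound 1, compound 2 and compound 4, as each gives only a limit in this assay: the limit of > 100000 nM in this assay, at which 3 of the 4 values shown sit.

The compounds shown leave open whether chloro in place of hydrogen on an aromatic carbon of the shared core changes inhibition at all.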